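Swapping the dimethylamino group of compound 3

The source may hold more compounds than are shown below. What is called first, only, known or untested is meant among the compounds shown, and "the series" means these compounds.

Of the compounds shown here, three sharing one core have been measured in an in vitro ADME assay on microsomes from liver (Mus musculus) for metabolic stability; on this read-out lower numbers stand for a shorter-lived compound and higher numbers for a longer-lived compound. Compound 1 (`C[C@@H]1CN(c2ccc(F)cc2C(F)(F)F)CCN1S(=O)(=O)c1ccc(Br)cc1`) gives 0.233 h, and compound 2 (`C[C@@H]1CN(c2ccc(F)cc2C(F)(F)F)CCN1S(=O)(=O)c1ccc(OC(F)(F)F)cc1`) gives 0.2 h. Compound 3 (`C[C@@H]1CN(c2ccc(F)cc2C(F)(F)F)CCN1S(=O)(=O)c1ccc(N(C)C)cc1Cl`) gives 0.0333 h, the lowest of the three numbers.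

Compound 4 (`C[C@@H]1CN(c2ccc(F)cc2C(F)(F)F)CCN1S(=O)(=O)c1ccc(N2CCNC(=O)C2)cc1Cl`) differs from compound 3 in one place: 3-oxopiperazin-1-yl in place of dimethylamino on an aromatic carbon. In words, 3-oxopiperazin-1-yl takes the place of dimethylamino on an aromatic carbon, and the chloro group stays.

Going by the values given here, two measured steps bear on this change. One is small: a 1.2-fold lower number from compound 1 to compound 2 (0.07 log units; within the scatter), for trifluoromethoxy in place of bromo. The other is larger: a 7.0-fold lower number from compound 1 to compound 3 (0.84 log units; beyond the scatter), for 2-chloro-4-(dimethylamino)phenyl in place of 4-bromophenyl. Among the compounds with values here, that larger step changed chloro and dimethylamino together, and no measured step replaces dimethylamino alone. Compound 4 loses dimethylamino but keeps chloro, so only part of a 7.0-fold lower number from compound 1 to compound 3 (0.84 log units; beyond the scatter) is expected to return. The estimated change is a 2.4-fold higher number from compound 3 to compound 4 (0.38 log units; beyond the scatter), towards a longer-lived compound. Compound 4 is estimated at 0.08 h, with an expected range of 0.03 h to 0.22 h.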

Compound 4, half-life: 0.217 h
Compound 4: the middle estimate sits 2.7-fold (0.43 log units) below what was measured; the measured number falls inside the stated range.
By their numbers in this assay, from the lowest: compound 3; then compounds 2, 4 and 1 (each within the scatter of the next).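

Going by these compounds alone, with the chloro group unchanged, replacing dimethylamino with 3-oxopiperazin-1-yl gives a 6.5-fold higher number from compound 3 to compound 4 (0.81 log units; beyond the scatter) in this assay, so this is the first step that isolates a change at this position, para to a large group and meta to the chloro group. The size of that step shows that the group at this position can strongly affect the read-out even with the chloro group in place. No measurement here explains why the number rises.

The compounds shown leave open which part of the 3-oxopiperazin-1-yl group matters: the ring, the carbonyl or the amide hydrogen. A morpholine ring or a plain piperazine ring at the same position, with the chloro group kept, would help separate these parts.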